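Epimer at the ring stereocentre of a phosphoserine partial agonist

The source may hold more compounds than are shown below. What is called first, only, known or untested is meant among the compounds shown, and "the series" means these compounds.

Measured in an assay on HEK293-A cells with probable G-protein coupled receptor 34 (Mus musculus) as the target, with a stated time of 1.5 h; on this read-out lower numbers stand for smaller maximal responses and higher numbers for larger maximal responses:
- compound 1 `N[C@@H](COP(=O)(O)O[C@@H]1C=CCO[C@@H]1COC(=O)CCc1ccccc1OCc1cccc(Oc2ccccc2)c1)C(=O)O`: 0.2
- compound 2 `CCCCCCCCCCCOc1ccccc1CCC(=O)OC[C@H]1OCC=C[C@H]1OP(=O)(O)OC[C@H](N)C(=O)O`: 0.086

Compound 1 stands highest of the two numbers; its nearest neighbour is compound 2, which sits lower by a gap beyond the usual scatter. Among the measured compounds shown here, no single-change pair among the measured compounds is available, so the size of a stereochemical step here is unknown.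

Compound 3 `N[C@@H](COP(=O)(O)O[C@H]1C=CCO[C@@H]1COC(=O)CCc1ccccc1OCc1cccc(Oc2ccccc2)c1)C(=O)O` is the next compound to be measured in this assay. Relative to compound 1 the change is the two compounds have the same atoms and bonds; at least one stereo element is drawn with a configuration in one of them and without one in the other: 1 of 4 stereo elements differ; a stereocentre at a saturated ring carbon is drawn R in compound 1 and S in compound 3. Nothing leaves and nothing enters.

For the measured compounds named here, with no comparable step in hand, the expectation rests on compound 1 alone, whose 0.2 is itself a modest response. An inversion at a ring stereocentre is expected to shift the response downward by a small amount, possibly within the scatter, with a wide range either way. Compound 3 is expected to give 0.15, within 0.03 to 0.35. The estimate corresponds to an expected step a number 0.050 lower from compound 1 to compound 3 (within the scatter).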

Compound 3, intrinsic activity: the largest response reached, as a fraction of the reference agonist's: 0.25
Compound 3: the middle estimate sits 0.10 below what was measured; low and high end bracket the measured number.
By their numbers in this assay, from the lowest: compound 2; then compounds 1 and 3 (each within the scatter of the next).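

In this assay, the series now has its first single-change step: with all else in the core of compound 1 held fixed, switching the saturated ring carbon from R to S gives a number 0.050 higher from compound 1 to compound 3 (within the scatter). The configuration at this ring carbon therefore does not move the maximal response beyond the scatter in this structural setting, and compound 3 still gives only 0.25. One caveat applies to reading this step as a clean change of configuration: the fact that one of compounds 1 and 3 is drawn with a defined configuration and the other without, at the place where they differ

Going by these compounds, whether the same change behaves alike with the long alkyl ether of compound 2 remains open, as does the role of the other stereo elements. Also open, on these data alone, is how the maximal response would respond to a phosphonate in place of the phosphate.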